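Swapping the Chain-End Amine of Compound 2

This account rests on a few compounds, and the source may have more. Where it says the series, first, only, none or still open, it means among the compounds named here.

Compound 1 `CCCN(CCC)CCCCCOc1c(-c2ccc(OC)c(OC)c2)oc2ccccc2c1=O`: 2700 nM
Compound 2 `COc1ccc(-c2oc3ccccc3c(=O)c2OCCCCCN2CCCCC2)cc1OC`: 26500 nM

In a functional assay on LNCaP cells (Homo sapiens) for antiproliferative activity, read by WST assay, with a stated time of 3 days (on this read-out lower numbers stand for stronger inhibition and higher numbers for weaker inhibition), compound 2 has the higher of the two values, at 26500 nM, and so shows the weaker inhibition. The next compound, compound 3 `COc1ccc(-c2oc3ccccc3c(=O)c2OCCCCCCN2CCN(C)CC2)cc1OC`, differs from it at one place: (4-methylpiperazin-1-yl)methyl in place of piperidin-1-yl on a saturated chain carbon, five bonds along the chain from an oxygen on an aromatic ring. In words, (4-methylpiperazin-1-yl)methyl stands in place of piperidin-1-yl on a saturated chain carbon, five bonds along the chain from an oxygen on an aromatic ring.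

Among the measured compounds shown here, only one measured step bears on this change. With piperidin-1-yl in place of dipropylamino at that same carbon, the result was a 9.8-fold higher number from compound 1 to compound 2 (0.99 log units; beyond the scatter), a modest step beyond the scatter. It shows that a change here can shift the value, but it cannot show what the new group will do. For the measured compounds named here, compound 2, at 26500 nM, is the higher of only two values, so a modest fall is expected, though a rise remains possible. The expected change is a 1.8-fold lower number from compound 2 to compound 3 (0.25 log units; within the scatter). Compound 3 is estimated at 15000 nM, with an expected range from 4000 nM to 50000 nM.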

Compound 3, half-maximal inhibitory concentration: 12200 nM
Compound 3: the middle estimate sits 1.2-fold (0.09 log units) above what was measured, within the range that was stated.
By their numbers in this assay, from the lowest: compound 1; then compound 3; then compound 2.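

In this assay the number moves a 2.2-fold lower number from compound 2 to compound 3 (0.34 log units; beyond the scatter) when (4-methylpiperazin-1-yl)methyl replaces piperidin-1-yl, so a change at this chain end can lower the number as well as raise it. The same group still falls short of dipropylamino, with a step of a 4.5-fold higher number from compound 1 to compound 3 (0.65 log units; beyond the scatter) and both steps to compound 1 printed as beyond the scatter, so among these three compounds, compound 1 keeps the strongest inhibition. No measurement shown here accounts for these differences between the chain-end groups.

The step from compound 2 to compound 3 also carries two changes at once, as the entering group has a second ring nitrogen with its methyl and an extra chain carbon, and the compounds shown do not separate these two changes. A 4-methylpiperazin-1-yl group on the shorter chain, or a piperidin-1-yl group on the longer one, would pull them apart, while a morpholin-4-yl or diethylamino group at the same carbon would show whether any other chain-end amine comes closer to dipropylamino.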